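Triazine series: acetamido to (2-oxopropyl)amino step

A few compounds are considered here, and "the series" means these few. Any claim that something is new, unique, unknown or untested is made for them only; others in the source may bear on it.

Measured compounds:
compound 1 `Cc1cn2c(NC3CCCC3)nc(-c3ccccc3)nc2n1`, 41 nM
compound 2 `CC(=O)Nc1nc(-c2ccccc2)nc2nc(C)cn12`, 855 nM

In an assay on cell membranes for displacement of a labelled ligand from adenosine receptor A1 (Bos taurus) (a lower number here means a stronger inhibitor, a higher number a weaker inhibitor), compound 2 gives the highest number of the two measured; its nearest neighbour is compound 1, and the step of a 21-fold higher number from compound 1 to compound 2 (1.32 log units; beyond the scatter) separates them, well beyond the scatter. That step is the only measured one and it replaces a cyclopentyl on the ring nitrogen with an acetyl.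

Compound 3 `CC(=O)CNc1nc(-c2ccccc2)nc2nc(C)cn12` is not yet measured. It differs from compound 2 by 2-oxopropyl in place of acetyl on a nitrogen on an aromatic ring. The change reverses the character of the substituent on the ring nitrogen from acetyl back to an alkyl group, as in compound 1, though 2-oxopropyl is a shorter, non-cyclic chain than cyclopentyl. Among the measured compounds shown here, the one measured step bears on this only indirectly: it shows that the acetyl on nitrogen costs a large amount in this assay relative to an alkyl group. A partial recovery toward compound 1 is therefore expected, with a 4.3-fold lower number from compound 2 to compound 3 (0.63 log units; beyond the scatter) as the estimated step, smaller than the full loss seen from compound 1 to compound 2. Compound 3 is estimated at 200 nM, within 60 nM to 700 nM.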

Compound 3, inhibition constant: 12 nM
For compound 3 the middle estimate is 17-fold (1.22 log units) above the measured one; the whole stated range lies above it.
By their numbers in this assay, from the lowest: compound 3; then compound 1; then compound 2.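

In this assay, the step from acetamido to (2-oxopropyl)amino gives a 71-fold lower number from compound 2 to compound 3 (1.85 log units; beyond the scatter), so a carbonyl in the substituent on this nitrogen does not by itself carry the high number of compound 2, as 2-oxopropyl holds a carbonyl too. A ring in the substituent is also not required for a low number at this place: 2-oxopropyl has none, yet replacing cyclopentyl with it gives a 3.4-fold lower number from compound 1 to compound 3 (0.53 log units; beyond the scatter), and compound 3 therefore has the lowest number of the three. Nothing available accounts for either step.

The compounds shown do not separate the contribution of the carbonyl in 2-oxopropyl from that of the chain alone, a question that a plain propyl chain or a 2-hydroxypropyl group on the same nitrogen would address. As far as these compounds go, how far this place tolerates other substituents also stays open, including a longer chain carrying a ketone or a chain ending in an amine or a carboxylic acid.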